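Growing an Aryl Group on the Amino Nitrogen

A few compounds are considered here, and "the series" means these few. Any claim that something is new, unique, unknown or untested is made for them only; others in the source may bear on it.

Measured compounds:
compound 1, `CCc1nnc(-c2nsc3ccccc23)o1` — 18%
compound 2, `CNc1nnc(-c2nsc3ccccc23)o1` — 10%

Of the compounds shown here, two sharing one core have been tested in a functional assay on the whole organism for inhibition, with Rattus norvegicus as the target, with a stated time of 3.5 h, at a dose of 100 mg/kg by the oral route; a higher number here means more inhibition at the dose given (going by the name of the read-out), a lower number less inhibition. Compound 1 `CCc1nnc(-c2nsc3ccccc23)o1` gives 18% in this assay. Among the measured compounds shown here, compound 2 `CNc1nnc(-c2nsc3ccccc23)o1` gives 10% in this assay, the lower of the two numbers, but the only step, a number 8 percentage points lower from compound 1 to compound 2 (within the scatter), lies within the scatter, so the two numbers cannot be told apart.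

Compound 3 `Clc1ccc(Nc2nnc(-c3nsc4ccccc34)o2)cc1` is not yet measured. The change from compound 2 is 4-chlorophenyl in place of methyl on a nitrogen on an aromatic ring. For the measured compounds named here, no measured step bears on swapping a methyl for a 4-chlorophenyl on this nitrogen; the only step known, a number 8 percentage points lower from compound 1 to compound 2 (within the scatter), touched an aromatic carbon and was within the scatter. With such thin evidence, a step no larger than the scatter is expected for a number 5 percentage points higher from compound 2 to compound 3 (within the scatter). Compound 3 is therefore estimated at 15% in this assay, with a range from 0% to 40%.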

Compound 3, a percentage reported as inhibition, in the whole organism at one dose (the size of the read-out at that dose, not a potency): 10%
For compound 3 the middle estimate is 5 percentage points above the measured one; measured number inside the range.
By their numbers in this assay, from the lowest: compounds 2, 3 and 1 (each within the scatter of the next).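

On the nitrogen on the aromatic ring, 4-chlorophenyl in place of methyl brings in a whole six-membered aromatic ring, yet this assay shows no change at the digits printed from compound 2 to compound 3 (within the scatter). Up to now this nitrogen had carried only a methyl, so this is the first sign that it can hold a far larger group with no readable difference in the number at this single dose. No measurement at hand offers an explanation for this result.

All three compounds lie within the scatter of the next in the series, so no group tested so far stands apart from the others. On these data alone, whether a plain phenyl, a benzyl or a longer chain ending in a carboxylic acid on this nitrogen would move the number beyond the scatter remains open.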